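The source may report more compounds than this note shows. Statements on the series, on what has been measured and on what is new or still open speak of the compounds shown alone.

Working notes on the series. The read-out throughout is an assay on CHO cells for displacement of a labelled ligand from prostaglandin E2 receptor EP1 subtype (Homo sapiens); a lower number here means a stronger inhibitor, a higher number a weaker inhibitor. Compound 1 `CCc1ccccc1N(Cc1nnc(Cc2ccc(Cl)cc2)o1)S(=O)(=O)c1ccc(C)cc1` gives 398 nM in this assay. Compound 2 `CCc1ccccc1N(Cc1nnc(Cc2ccc(OC)cc2)o1)S(=O)(=O)c1ccc(C)cc1` carries a 4-methoxyphenyl on the chain carbon where compound 1 carries a chlorine-bearing ring; in this assay compound 2 gives 126 nM; 126 nM (2 entries), two entries that agree. Compound 3 `COc1ccc(Cc2nnc(CN(c3cccc(Cl)c3C)S(=O)(=O)c3ccc(C)cc3)o2)cc1` gives 6.31 nM in this assay and stands as the lowest of the two single numbers; the nearest number is that of compound 1, a gap beyond the scatter, while compound 2 stands as a further entry without a single number.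

The step from compound 3 to compound 4 `Cc1ccc(S(=O)(=O)N(Cc2nnc(Cc3ccc(Cl)cc3Cl)o2)c2cccc(Cl)c2C)cc1` is 2,4-dichlorophenyl in place of 4-methoxyphenyl on a saturated chain carbon bound to an aromatic carbon. Going by the values given here, no step between measured compounds covers this exchange directly. What the values of compound 1 and compound 2 show is that, between those two, the chlorine-bearing ring goes with the higher number and the 4-methoxyphenyl with the lower one. The expectation for compound 4 in this assay is therefore a rise in the number beyond the scatter, a weaker inhibitor than compound 3, though not a collapse of binding. The estimate for compound 4 is 25 nM, with a range from 8 nM to 80 nM. The step expected is a 4.0-fold higher number from compound 3 to compound 4 (0.60 log units; beyond the scatter).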

Compound 4, half-maximal inhibitory concentration: 63.1 nM
Estimate against measurement, compound 4: 2.5-fold (0.40 log units) below; the measured number falls inside the stated range.
By their numbers in this assay, from the lowest: compound 3; then compound 4; then compound 1.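

In this assay, going by these compounds alone, 2,4-dichlorophenyl in place of 4-methoxyphenyl on a saturated chain carbon bound to an aromatic carbon gives a 10-fold higher number from compound 3 to compound 4 (1.00 log units; beyond the scatter), the first step that reads this exchange directly on one shared core. The direction matches the printed values of the earlier pair, where compound 1 with its chlorine-bearing ring gives 398 nM and compound 2 with 4-methoxyphenyl gives 126 nM; 126 nM (2 entries), so in both pairs the 4-methoxyphenyl goes with the lower number, and the change is not a loss of binding, as compound 4 still gives 63.1 nM. No measurement at hand accounts for the step, so the reason for this rise stays unexplained.

The compounds shown leave open how a single chlorine would read on the core of compound 3, so the 4-chlorophenyl group there would be needed to separate the share of each chlorine in the step. Also open, on these data alone, is how a group of a different kind at this place, such as an unsubstituted phenyl, a pyridine ring or a carboxylic acid, would stand in this assay.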